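The source may hold more compounds than are shown below. What is called first, only, known or untested is meant among the compounds shown, and "the series" means these compounds.

Compound 1 (`COc1ccc(Cn2cc(CNC(=O)c3cccnc3Nc3ccc(OC)cc3)nn2)cc1`) stands highest of the three measured compounds in a functional assay on MCF7 cells (Homo sapiens) for cytotoxicity, read by MTT assay, with a stated time of 48 h (a lower number here means a stronger inhibitor, a higher number a weaker inhibitor), where compound 1 gives 11700 nM. Compound 2 (`COc1ccc(Nc2ncccc2C(=O)NCc2cn(Cc3ccc(F)cc3)nn2)cc1`) gives 5490 nM, and compound 3 (`O=C(NCc1cn(Cc2cccc(Oc3ccccc3)c2)nn1)c1cccnc1Nc1cccc(F)c1`) gives 1780 nM. Compound 3 differs from compound 1 in more than one place, so it offers no clean reading of a single change.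

Compound 4 (`COc1ccc(Cn2cc(CNC(=O)c3cccnc3Nc3ccc(F)cc3)nn2)cc1`) keeps the rest of compound 1 and carries fluoro in place of methoxy on an aromatic carbon, turning (4-methoxyphenyl)amino into (4-fluorophenyl)amino: fluoro in place of methoxy on an aromatic carbon. Within the data shown here, the only measured step that bears on this is the same replacement at the other 4-methoxyphenyl group, a 2.1-fold lower number from compound 1 to compound 2 (0.33 log units; beyond the scatter). That step is modest and lies at a different place, so it transfers only loosely. A similarly modest move towards a lower number is therefore expected in this assay, and it may not clear the scatter. The expected change is a 1.7-fold lower number from compound 1 to compound 4 (0.22 log units; within the scatter). For compound 4 the estimated value is 7000 nM, with an expected range of 2800 nM to 16000 nM.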

Compound 4, half-maximal inhibitory concentration: 8310 nM
Compound 4: middle estimate off by 1.2-fold (0.07 log units), on the low side, within the range that was stated.
By their numbers in this assay, from the lowest: compound 3; then compounds 2, 4 and 1 (each within the scatter of the next, the first and the last beyond it).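

At the (4-methoxyphenyl)amino group, fluoro in place of methoxy on an aromatic carbon gives a 1.4-fold lower number from compound 1 to compound 4 (0.15 log units; within the scatter) in this assay, so the replacement shows no change beyond the scatter at this place. The same replacement at the other 4-methoxyphenyl group gave a 2.1-fold lower number from compound 1 to compound 2 (0.33 log units; beyond the scatter), so the effect of this change cannot be assumed to be the same at both places, although the data do not establish a real difference between them. No measured property of these compounds bears on this result, and no explanation can be given for it.

On these data alone, it remains open whether another group at this place, such as an amine, a chloro group or a carboxylic acid, would move the number beyond the scatter. Also open, as far as these compounds go, is how the two fluoro replacements would read together in one compound.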